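This account rests on a few compounds, and the source may have more. Where it says the series, first, only, none or still open, it means among the compounds named here.

Values measured in a physicochemical assay for solubility, read by LC-MS, in phosphate buffer, with a stated time of 24 h, at pH 7.4; a higher number here means a more soluble compound, a lower number a less soluble compound:

Compound 1 `Cn1cc(-c2cnc(NCc3c(F)ccc4c3CCO4)c3cn[nH]c(=O)c23)cn1`: 1000 nM
Compound 2 `COCCC(=O)Nc1cnc(NCc2c(F)ccc3c2CCO3)n2cnnc12`: 980000 nM
Compound 3 `CC(=O)N1CCC(c2cnc(NCc3c(F)ccc4c3CCO4)c3cn[nH]c(=O)c23)CC1`: < 2000 nM, which is a limit of the assay and not a number

Compound 2 holds the higher of the two actual numbers, and the gap from compound 1 to compound 2 lies well beyond the scatter. Compound 4 `O=C(Nc1cnc(NCc2c(F)ccc3c2CCO3)n2cnnc12)c1ccccc1` differs from compound 2 by phenyl in place of 2-methoxyethyl on a carbonyl carbon.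

Going by the values given here, the only measured step is a step that the limit leaves unreadable from compound 1 to compound 3. Among the compounds with values here, it concerns a different change and offers no size for this one, so no measured step bears directly on the new compound. The expectation therefore rests on the values alone. Compound 2 starts from 980000 nM, which leaves far more room to fall than to rise, while compound 1 shows 1000 nM. A clear fall in this assay is expected, with the estimated step being a 16-fold lower number from compound 2 to compound 4 (1.21 log units; beyond the scatter), though with wide uncertainty. Compound 4 is estimated at 60000 nM, with an expected range of 5000 nM to 400000 nM.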

Compound 4, solubility: 2000 nM
Beside the measured number, compound 4's estimate is 30-fold (1.48 log units) above it; the whole stated range lies above it.
By their numbers in this assay, from the lowest: compounds 1 and 4 (each within the scatter of the next); then compound 2.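

Going by these compounds alone, compound 2 and compound 4 give the first readable step for a change on this carbonyl carbon, whose other neighbour is an amide-type nitrogen: in this assay, phenyl in place of 2-methoxyethyl gives a 490-fold lower number from compound 2 to compound 4 (2.69 log units; beyond the scatter). The only earlier step concerns a different change and cannot be read, so this is the first size available for any change among these compounds. It shows that this place is far from indifferent to the group it carries, though no measurement shown accounts for the size of the step.

A single pair does not separate the arrival of the aromatic ring from the departure of the ether oxygen in 2-methoxyethyl. On the same carbonyl carbon, cyclohexyl, a plain propyl chain or a chain bearing an amine would each bear on that question.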